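A Thioether Side Chain on the Shared Core

The source may report more compounds than this note shows. Statements on the series, on what has been measured and on what is new or still open speak of the compounds shown alone.

Measured so far:
compound 1 `Cc1cn2cccc(OCc3ccccc3)c2n1`: 62%
compound 2 `[C-]#[N+]Cc1c(C)nc2c(OCc3ccccc3)cccn12`: 96%
compound 3 `COCc1c(C)nc2c(OCc3ccccc3)cccn12`: 99%

All three were tested in a functional assay on the whole organism with Rattus norvegicus as the target, with a stated time of 4 h, at a dose of 40 mg/kg by the intraperitoneal route; on this read-out higher numbers stand for more inhibition at the one dose given (going by the name of the read-out) and lower numbers for less inhibition. Compound 1 stands lowest of the three numbers; its nearest neighbour is compound 2, its furthest compound 3, and both lie beyond the scatter above it.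

Compound 4 `CCSCc1c(C)nc2c(OCc3ccccc3)cccn12` is the next compound of interest. It differs from compound 1 in one place: (ethylsulfanyl)methyl in place of hydrogen on an aromatic carbon.

Among the compounds with values here, two measured steps bear on this change, since each also replaces a hydrogen on that same aromatic carbon of compound 1 with a short chain. In this assay the step of a number 34 percentage points higher from compound 1 to compound 2 (beyond the scatter) and the step of a number 37 percentage points higher from compound 1 to compound 3 (beyond the scatter) were both large and upward, while the step of a number 3 percentage points higher from compound 2 to compound 3 (within the scatter) shows that swapping one chain for another of similar size made no difference beyond the scatter. A similarly large upward step is therefore expected for compound 4, namely a number 28 percentage points higher from compound 1 to compound 4 (beyond the scatter). Compound 4 is estimated at 90%, within a range from 70% to 100%.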

Compound 4, a percentage reported as inhibition, in the whole organism at one dose (the size of the read-out at that dose, not a potency): 36%
The estimate for compound 4 lay 54 percentage points above the measured number; the whole stated range lies above it.
By their numbers in this assay, from the lowest: compound 4; then compound 1; then compounds 2 and 3 (each within the scatter of the next).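

In this assay, a chain on this aromatic carbon does not always raise the number: (ethylsulfanyl)methyl gives a number 26 percentage points lower from compound 1 to compound 4 (beyond the scatter), the only downward step from compound 1 among the compounds shown. What the chain is made of therefore matters, not just its presence: ethylsulfanyl in place of methoxy gives a number 63 percentage points lower from compound 3 to compound 4 (beyond the scatter), and the change from the other short chain gives a number 60 percentage points lower from compound 2 to compound 4 (beyond the scatter). Short chains on this one carbon can thus fall on either side of compound 1, with compound 2 and compound 3 above it and compound 4 below it.

Nothing available here accounts for this fall. Still open, as far as these compounds go, is whether the sulfur or the ethyl end counts, which an ethoxymethyl chain, a (methylsulfanyl)methyl chain or an aminomethyl group on the same carbon could help separate.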